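Sulfonyl aryl variation in an HSP60/HSP10 inhibitor series

The source may report more compounds than this note shows. Statements on the series, on what has been measured and on what is new or still open speak of the compounds shown alone.

Measured compounds:
- compound 1, `O=S(=O)(Nc1ccc2oc(-c3ccccc3)nc2c1)c1ccc(Cl)cc1`: in an assay on cells for inhibition of HSP60/HSP10 (Homo sapiens), with a stated time of 60 min (a higher number here means a weaker inhibitor, a lower number a stronger inhibitor), compound 1 gives > 100000 nM, which is a limit of the assay and not a number.
- compound 2, `COc1ccccc1S(=O)(=O)Nc1ccc2oc(-c3ccccc3)nc2c1`: in this assay compound 2 gives > 100000 nM, again a limit and not a number.
- compound 3, `O=S(=O)(Nc1ccc2oc(-c3ccccc3)nc2c1)c1ccccc1O`: in this assay compound 3 gives 85000 nM.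

Within the data shown here, compound 3 thus holds the only actual number in the set; the two other entries rest at the limit of > 100000 nM in this assay, at which 2 of the 3 values shown sit. The steps of an at least 1.1-fold lower number from compound 1 to compound 3 (0.07 log units; that floor lies within the scatter) and an at least 1.1-fold lower number from compound 2 to compound 3 (0.07 log units; that floor lies within the scatter) are read against that limit, and their floors sit inside the scatter, so no ordering beyond scatter is established among the three.

Compound 4, `Cc1cccc(S(=O)(=O)Nc2ccc3oc(-c4ccccc4)nc3c2)c1`, is not yet measured. It differs from compound 3 as follows: 3-methylphenyl in place of 2-hydroxyphenyl on a sulfonyl sulfur. The group entering carries neither donor nor acceptor, and the two compounds without a donor on that ring, compound 1 and compound 2, both stopped at the limit. The step of a 1.8-fold higher number from compound 3 to compound 4 (0.25 log units; within the scatter) is therefore expected to go towards weaker inhibition, though by an amount that may well not exceed the scatter. For compound 4 the estimate in this assay is 150000 nM, with a range from 60000 nM to 400000 nM, and a fair chance that only a limit is reported.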

Compound 4, half-maximal inhibitory concentration: > 100000 nM
Compound 4: no number, only a limit; the forecaster's own chance of this, stated with the estimate: 65%; the middle value does not contradict the limit.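

In this assay compound 4 gives > 100000 nM, which is a limit and not a number, and a carbon-only aryl group on the sulfonyl sulfur adds one more entry to the compounds at that limit: the limit of > 100000 nM in this assay, at which 3 of the 4 values shown sit. Replacing 2-hydroxyphenyl with 3-methylphenyl, which has 0 hydrogen-bond donors and 0 hydrogen-bond acceptors, gives an at least 1.1-fold higher number from compound 3 to compound 4 (0.07 log units; that floor lies within the scatter), so this change establishes no order beyond the scatter. Compound 3, with 2-hydroxyphenyl, remains the only one of the four with an actual number in this assay, at 85000 nM. The steps to compound 4 from compound 1 and compound 2 cannot be read, with limits at both ends.

The compounds shown leave open whether the hydroxyl group of compound 3 has any real bearing on inhibition, since its value cannot be separated from the limit reached by the other three. Also open, as far as these compounds go, is whether an amine or a carboxylic acid on the aryl ring attached to the sulfonyl sulfur would give a value clearly beyond the scatter from that of compound 3.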